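A few compounds are considered here, and "the series" means these few. Any claim that something is new, unique, unknown or untested is made for them only; others in the source may bear on it.

Among the compounds with values here, compound 1 `Cc1nc2c3ccccc3ccc2c2nc3c(ccc4ccccc43)c(-c3cccnc3)c12` stands highest of the two numbers measured so far in a functional assay, read by spectrophotometry, with a stated time of 30 min (a higher number here means a weaker inhibitor, a lower number a stronger inhibitor), where compound 1 gives 98.2 ug/mL. Its nearest neighbour is compound 2 `Cc1nc2c3ccccc3ccc2c2nc3c(ccc4ccccc43)c(-c3cc([N+](=O)[O-])ccc3N)c12`, which in this assay gives 93.1 ug/mL; the step of a 1.1-fold lower number from compound 1 to compound 2 (0.02 log units; within the scatter) lies within the scatter. Compound 3 `Cc1nc2c3ccccc3ccc2c2nc3c(ccc4ccccc43)c(C)c12` has not been measured. It differs from compound 1 in one place: methyl in place of pyridin-3-yl on an aromatic carbon. Within the data shown here, no measured step exchanges pyridin-3-yl for methyl. Among the measured compounds shown here, the only step at this carbon, a 1.1-fold lower number from compound 1 to compound 2 (0.02 log units; within the scatter), puts 2-amino-5-nitrophenyl in place of pyridin-3-yl and stays within the scatter, so the one exchange seen at this carbon did not move the number beyond the scatter. With nothing else to go on, the expected step is a 1.0-fold lower number from compound 1 to compound 3 (0.00 log units; within the scatter), that is none beyond the scatter. For compound 3 the estimated value in this assay is 98 ug/mL, within the range 50 ug/mL to 200 ug/mL.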

Compound 3, half-maximal inhibitory concentration: 129 ug/mL
Beside the measured number, compound 3's estimate is 1.3-fold (0.12 log units) below it; the measured number falls inside the stated range.
By their numbers in this assay, from the lowest: compounds 2, 1 and 3 (each within the scatter of the next).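

At this aromatic carbon, opposite the ring nitrogen, the step in this assay is a 1.3-fold higher number from compound 1 to compound 3 (0.12 log units; within the scatter), and the second step is a 1.4-fold higher number from compound 2 to compound 3 (0.14 log units; within the scatter), so a substituent with no ring stays within the scatter of both aryl-type groups. Pyridin-3-yl and 2-amino-5-nitrophenyl are therefore not shown to be needed here: methyl, with no ring and no hydrogen-bond acceptor, holds the number in the same band. Nothing measured on these compounds explains why the three numbers sit together.

Whether any group at this carbon can move the number beyond the scatter stays open, since a carboxylic acid, a primary amine and a longer alkyl chain such as butyl are not among the compounds shown. From the compounds shown here alone, all three compounds also share one core, so the effect of changes elsewhere on it remains unknown.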